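The source may report more compounds than this note shows. Statements on the series, on what has been measured and on what is new or still open speak of the compounds shown alone.

Working notes on the series, measured in an assay on isolated protein for binding affinity to corticotropin-releasing factor receptor 1 (Homo sapiens); a lower number here means a stronger inhibitor, a higher number a weaker inhibitor.

Compound 1, `CC(=O)/C(=N\Nc1ccccc1C)N(C)c1cccc(Cl)c1`, returns only a limit in this assay, > 10000 nM, and no number. Compound 2, `CC(=O)/C(=N\c1cccc(Cl)c1)NNc1ccc(Br)cc1`, gives 1460 nM in this assay. Compound 3, `CC(=O)/C(=N\c1cccc(C)c1)NNc1ccccc1C`, gives 526 nM in this assay, the lowest of the two numbers available, with compound 2 the nearest at a gap that lies beyond the usual scatter. The limit seen for compound 1 is noted as the limit of > 10000 nM in this assay, at which 1 of the 3 values shown sits.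

Compound 4, `CC(=O)/C(=N\c1cccc(C(F)(F)F)c1)NNc1ccccc1C`, differs from compound 3 in one place: trifluoromethyl in place of methyl on an aromatic carbon, on an aromatic carbon of a six-membered aromatic ring of carbon only, meta to a large group. Among the compounds with values here, no measured pair shows this change, so its size and direction rest on no precedent here. A modest shift is expected in this assay, with the direction open; the step from compound 3 to compound 4 is estimated at a 1.3-fold higher number from compound 3 to compound 4 (0.12 log units; within the scatter). Compound 4 is expected to give about 700 nM in this assay, within a range from 200 nM to 2500 nM.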

Compound 4, inhibition constant: 291 nM
Beside the measured number, compound 4's estimate is 2.4-fold (0.38 log units) above it, and the stated range covers the measured number.
By their numbers in this assay, from the lowest: compounds 4 and 3 (each within the scatter of the next); then compound 2. At a limit, above all of these: compound 1.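

In this assay, the series now has its first step between compounds that differ in one place: a 1.8-fold lower number from compound 3 to compound 4 (0.26 log units; within the scatter) for trifluoromethyl in place of methyl on an aromatic carbon. On this carbon, meta to a large group, the two groups therefore cannot be told apart in this assay, even though the heavy-atom count of the group rises from 1 to 4. None of the measurements at hand bears on the cause of this step.

Open, as far as these compounds go, is how a group of another kind would fare on this same carbon, such as an amine, a carboxylic acid, a nitrile or a longer chain. Also open, from the compounds shown here alone, is whether trifluoromethyl in place of methyl gives a comparable step on other aromatic carbons of the series.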